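A Second Chloro Group on the Ring of Compound 2

A few compounds are considered here, and "the series" means these few. Any claim that something is new, unique, unknown or untested is made for them only; others in the source may bear on it.

Compound 2 `Cc1c(O)c(=O)ccn1CC(=O)N/N=C1\C(=O)N(CC(=O)Nc2cccc(Cl)c2)c2ccccc21` and compound 1 `CC(=O)Nc1ccc(NC(=O)CN2C(=O)/C(=N\NC(=O)Cn3ccc(=O)c(O)c3C)c3ccccc32)cc1` are the two compounds measured in a functional assay on MCF7 cells (Homo sapiens) for cytotoxicity, read by MTT assay, with a stated time of 48 h; a higher number here means that more compound is needed for the effect, a lower number that less compound is needed. Compound 2 gives 34600 nM, and compound 1 gives 51900 nM. The two differ only in the group on the amide-type nitrogen, a 3-chlorophenyl in compound 2 in place of a 4-acetamidophenyl in compound 1, and the step of a 1.5-fold lower number from compound 1 to compound 2 (0.18 log units; within the scatter) stays within the scatter, so neither compound stands apart from the other.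

Compound 3 `Cc1c(O)c(=O)ccn1CC(=O)N/N=C1\C(=O)N(CC(=O)Nc2cc(Cl)cc(Cl)c2)c2ccccc21` is not yet measured. It differs from compound 2 by chloro in place of hydrogen on an aromatic carbon, a chloro in place of hydrogen on an aromatic carbon, so that the 3-chlorophenyl becomes a 3,5-dichlorophenyl. Among the measured compounds shown here, the only measured step, from compound 1 to compound 2, also altered this ring, and it moved the number little. For the measured compounds named here, no measured step shows a chloro entering for a hydrogen. Compound 3 is therefore expected to sit close to compound 2, with a step of a 1.2-fold lower number from compound 2 to compound 3 (0.06 log units; within the scatter), and its estimated value is 30000 nM, within a range from 12000 nM to 80000 nM.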

Compound 3, half-maximal effective concentration: 35100 nM
For compound 3 the middle estimate is 1.2-fold (0.07 log units) below the measured one, and the stated range covers the measured number.
By their numbers in this assay, from the lowest: compounds 2, 3 and 1 (each within the scatter of the next).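

Among the compounds shown here, this is the first measured case of a chloro entering for a hydrogen, here on an aromatic carbon of the six-membered ring that already carries a chloro group, and in this assay the step reads as follows (a 1.0-fold higher number from compound 2 to compound 3 (0.01 log units; within the scatter)), so the two numbers cannot be told apart. Compared with compound 1, the 3,5-dichlorophenyl gives the same kind of result as the 3-chlorophenyl did (a 1.5-fold lower number from compound 1 to compound 3 (0.17 log units; within the scatter)), so all three groups seen so far on the amide-type nitrogen give numbers within the scatter of one another. No measurement is at hand that could account for this lack of a visible difference.

What these compounds leave open is whether a different kind of group on this ring, such as an amine, a carboxylic acid or a methoxy group, would give a step beyond the scatter. As far as these compounds go, it also remains open whether a longer chain between the amide-type nitrogen and the ring, or a change elsewhere on the shared core, would do so.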